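The compounds below may be only part of what the source reports. "The series", "measured", "known", "first", "only" and "open" are said of these compounds alone.

Compound 1 `CC(Nc1ccc(S(=O)(=O)Nc2nccs2)cc1Cl)c1ccccc1`: 81 mL/min/kg
Compound 2 `C[C@H](Nc1ccc(S(=O)(=O)Nc2nccs2)cc1Cl)c1ccccc1`: 62 mL/min/kg

Both compounds were measured in an ADME assay on microsomes from liver (Homo sapiens) for metabolic stability, read by LC-MS, using NADPH, with a stated time of 60 min, tested at 1 uM; a lower number here means slower removal, a higher number faster removal of the compound. For the measured compounds named here, compound 2, at 62 mL/min/kg, lies within the scatter of compound 1, the only other compound with a measured value, so the two cannot be separated on these numbers. The measured step between them is a 1.3-fold lower number from compound 1 to compound 2 (0.12 log units; within the scatter). The only structural difference behind that step is the fact that one of compounds 1 and 2 is drawn with a defined configuration and the other without, at the place where they differ.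

Compound 3 `C[C@@H](Nc1ccc(S(=O)(=O)Nc2nccs2)cc1Cl)c1ccccc1` has yet to be measured. Its relation to compound 2 is the two compounds have the same atoms and bonds and differ only in configuration as drawn: 1 of 1 stereo elements differ; a stereocentre at a saturated chain carbon is drawn S in compound 2 and R in compound 3. Going by the values given here, the step from compound 1 to compound 2 is the only measured evidence on this stereocentre, and it is small. If compound 1 contains both configurations, compound 3 could read somewhat higher than compound 2, but no step beyond the scatter is expected in this assay. The expected step is a 1.4-fold higher number from compound 2 to compound 3 (0.14 log units; within the scatter). For compound 3 the estimated clearance is 85 mL/min/kg, with an expected range of 50 mL/min/kg to 140 mL/min/kg.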

Compound 3, clearance: 102 mL/min/kg
The estimate for compound 3 lay 1.2-fold (0.08 log units) below the measured number; low and high end bracket the measured number.
By their numbers in this assay, from the lowest: compounds 2, 1 and 3 (each within the scatter of the next).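

With both drawn configurations now available, the stereocentre at the saturated chain carbon can be compared directly in this assay, and inverting it from S to R gives a 1.6-fold higher number from compound 2 to compound 3 (0.22 log units; within the scatter) in clearance. This direct comparison was not available from the earlier pair, which set a defined S centre against one drawn without a configuration, and it shows that the two defined forms cannot be separated on these numbers. The compound drawn without a configuration cannot be separated from the R form either, with a 1.3-fold higher number from compound 1 to compound 3 (0.10 log units; within the scatter), so this position shows no demonstrated preference for either configuration in this assay, and the comparison of the two defined forms rests on a single structural difference: the fact that compounds 2 and 3 differ only in the configuration as drawn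

The compounds shown leave open whether compound 1 holds both configurations and in what proportion, and so how its number should be read against those of the two defined forms. They also leave open whether configuration at this carbon would still make so little difference with a longer chain on that carbon, or with a carboxylic acid on the shared core.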